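A Carbonyl Inserted into a Weakly Active Compound

This account rests on a few compounds, and the source may have more. Where it says the series, first, only, none or still open, it means among the compounds named here.

Compound 1 (`O=C(NNc1ccc(F)cc1)c1ccc(NS(=O)(=O)c2cnc(O)nc2O)cc1`) gives > 20000 nM in a functional assay on MDA-MB-231 cells (Homo sapiens) for antiproliferative activity, read by MTT assay, with a stated time of 24 h (a higher number here means a weaker inhibitor, a lower number a stronger inhibitor), and that figure is a limit, not a measured number. Its place on the scale rests only on the limit of > 20000 nM in this assay, at which 1 of the 2 values shown sits, and no exact number exists for it. Among the measured compounds shown here, compound 2 (`O=C(NNc1ccccc1Cl)c1ccccc1NS(=O)(=O)c1cnc(O)nc1O`) gives 18900 nM as a true number in this assay and is the only exact reading so far.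

Compound 3 (`O=C(NNC(=O)c1ccc(NS(=O)(=O)c2cnc(O)nc2O)cc1)c1ccc(F)cc1`) is still unmeasured and departs from compound 1 in one place ((4-fluorophenyl)carbonyl in place of 4-fluorophenyl on an amine nitrogen) where (4-fluorophenyl)carbonyl stands in place of 4-fluorophenyl on an amine nitrogen. For the measured compounds named here, no measured pair of compounds shows what a change of this kind does, so any forecast must stay modest. Because compound 2 gives 18900 nM in the same weak region, no shift beyond the usual scatter is expected in either direction. As far as these compounds go, the estimated move is small (a number no higher from compound 1 to compound 3 (the limit leaves the size open)) and the direction remains open. For compound 3 the estimated value is 20000 nM with an expected range from 8000 nM to 50000 nM in this assay once a reading exists.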

Compound 3, half-maximal inhibitory concentration: > 20000 nM
Compound 3: a limit, no number; the forecaster's own chance of this, stated with the estimate: 55%; the middle value sits exactly at the limit.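

In this assay compound 1 and compound 3 each give only a limit and not an exact number, so the step between them cannot be read. The compounds shown leave open whether (4-fluorophenyl)carbonyl in place of 4-fluorophenyl on an amine nitrogen changes antiproliferative activity at all, in either direction.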